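Working notes: propyl to 3-(methylsulfonyl)propyl

The source may hold more compounds than are shown below. What is called first, only, known or untested is meant among the compounds shown, and "the series" means these compounds.

Measured so far in a physicochemical assay for lipophilicity, read by HPLC, in phosphate buffer, measured as octanol-water partition, at pH 7.4, tested at 100 uM (on this read-out lower numbers stand for lower lipophilicity and higher numbers for higher lipophilicity), for the series

- compound 1 `CCOc1cc(C)c(-c2cccc(CNc3ccc(OCC(=O)O)c(F)c3)c2)c(C)c1` gives 3.04
- compound 2 `CCCOc1cc(C)c(-c2cccc(CNc3ccc(OCC(=O)O)c(F)c3)c2)c(C)c1` gives 3.59
- compound 3 `CCCOc1ccc(-c2cccc(CNc3ccc(OCC(=O)O)c(F)c3)c2)c(C)c1` gives 3.37

Compound 3 stands within the scatter of compound 2 and beyond the scatter above compound 1. Compound 4 `Cc1cc(OCCCS(C)(=O)=O)ccc1-c1cccc(CNc2ccc(OCC(=O)O)c(F)c2)c1` is the next case, with methylsulfonyl in place of hydrogen on a saturated chain carbon, three bonds along the chain from an oxygen on an aromatic ring. Counted, the change reads methylsulfonyl in place of hydrogen on a saturated chain carbon, three bonds along the chain from an oxygen on an aromatic ring and turns propyl into 3-(methylsulfonyl)propyl.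

Among the compounds with values here, two measured steps bear on it only loosely. The chain step a number 0.55 log units higher from compound 1 to compound 2 (beyond the scatter) is modest and adds a methyl. The step of a number 0.22 log units lower from compound 2 to compound 3 (within the scatter) lies within the scatter and concerns an aromatic carbon. Within the data shown here, neither brings in a methylsulfonyl, so the series holds no direct precedent. In this assay a step opposite in direction to the chain step and larger in size is expected. The estimated step is a number 1.47 log units lower from compound 3 to compound 4 (beyond the scatter) and would lie beyond the scatter. For compound 4 the expected value is 1.9 with 1.4 to 2.4 as the estimated range.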

Compound 4, distribution coefficient: 1.59
Beside the measured number, compound 4's estimate is 0.31 log units above it; the measured number falls inside the stated range.
By their numbers in this assay, from the lowest: compound 4; then compound 1; then compounds 3 and 2 (each within the scatter of the next).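

In this assay, within the data shown here, the change from propyl to 3-(methylsulfonyl)propyl gives a number 1.78 log units lower from compound 3 to compound 4 (beyond the scatter) and is the only step that goes down beyond the scatter. Changes on this chain have now moved the read-out both ways: up with the added methyl in a number 0.55 log units higher from compound 1 to compound 2 (beyond the scatter) and down with methylsulfonyl, with the downward step the larger of the two. No measurement at hand accounts for the size of this step.

Open, on these data alone, is how an amine, a carboxylic acid or a sulfonamide on the same saturated chain carbon would compare with methylsulfonyl in this assay and whether 2-(methylsulfonyl)ethyl would give a step of similar size. Also open, as far as these compounds go, is whether the same change would give a similar step on the core of compound 2.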